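This account rests on a few compounds, and the source may have more. Where it says the series, first, only, none or still open, it means among the compounds named here.

Measured so far in a functional assay on HSC-2 cells (Homo sapiens) for cytotoxicity, with a stated time of 24 h; a higher number here means that more compound is tolerated, a lower number that less compound is tolerated:
- compound 1 `O=C1/C(=C/c2ccccc2)CCC/C1=C\c1cccc([N+](=O)[O-])c1`: 3700 nM
- compound 2 `O=C1/C(=C/c2ccc(F)cc2)CCC/C1=C\c1cccc([N+](=O)[O-])c1`: 2200 nM
- compound 3 `CN(C)c1ccc(/C=C2\CCC/C(=C\c3cccc([N+](=O)[O-])c3)C2=O)cc1`: 32000 nM

Of these, compound 3 has the highest number, at 32000 nM, and is separated from both others by more than the scatter. The next step leads to compound 4 `Cc1ccc(/C=C2\CCC/C(=C\c3cccc([N+](=O)[O-])c3)C2=O)cc1`, not yet measured. The change is methyl in place of dimethylamino on an aromatic carbon, para to a large group.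

For the measured compounds named here, two measured steps bear on this most directly: an 8.6-fold higher number from compound 1 to compound 3 (0.94 log units; beyond the scatter) and a 15-fold higher number from compound 2 to compound 3 (1.16 log units; beyond the scatter). In both, dimethylamino enters at this place. The remaining step, a 1.7-fold lower number from compound 1 to compound 2 (0.23 log units; within the scatter), lies within the scatter, so hydrogen and fluoro are not told apart here. No measured compound carries methyl at this place, so its behaviour is inferred rather than shown. Compound 4 is expected to fall close to compound 1 and compound 2, which gives an expected change of a 9.1-fold lower number from compound 3 to compound 4 (0.96 log units; beyond the scatter). For compound 4 the estimated value is 3500 nM, with an expected range of 1500 nM to 8500 nM.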

Compound 4, half-maximal cytotoxic concentration: 17000 nM
Beside the measured number, compound 4's estimate is 4.9-fold (0.69 log units) below it; the whole stated range lies below it.
By their numbers in this assay, from the lowest: compounds 2 and 1 (each within the scatter of the next); then compounds 4 and 3 (each within the scatter of the next).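

In this assay the change gives a 1.9-fold lower number from compound 3 to compound 4 (0.27 log units; within the scatter) and so does not tell methyl from dimethylamino at this place on the aromatic ring. Against hydrogen and fluoro, methyl gives a 4.6-fold higher number from compound 1 to compound 4 (0.66 log units; beyond the scatter) and a 7.7-fold higher number from compound 2 to compound 4 (0.89 log units; beyond the scatter) so the higher numbers here are not tied to dimethylamino alone: compound 3 and compound 4 form one pair, and compound 1 and compound 2 form another. Nothing measured here accounts for this split into two pairs.

Still open, from the compounds shown here alone, is where other groups at this place would fall, such as methoxy, chloro, a carboxylic acid or a longer chain like ethyl. Also open, going by these compounds, is whether the same two pairs would appear with the nitro group on the other aromatic ring replaced by another group.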